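The source may report more compounds than this note shows. Statements on the series, on what has been measured and on what is new or still open speak of the compounds shown alone.

Compound 1, `CCOC(=O)C1=C(S[C@@H]2CN[C@H](C(=O)Nc3cccc(C(=O)OCC)c3)C2)[C@H](C)[C@@H]2[C@@H]([C@@H](C)OC(=O)CC)C(=O)N12`, stands at the top of the three numbers measured in an ADME assay on the whole organism (plasma, strain Beagle) for pharmacokinetics, with Canis familiaris (Canis lupus familiaris) as the target, read by LC-MS, with a stated time of 8 h, at a dose of 10 mg/kg by the intraduodenal route; on this read-out higher numbers stand for higher exposure at the dose given and lower numbers for lower exposure: in this assay compound 1 gives 5350 ng.h/mL. Compound 2, `CC(C)C(=O)OCOC(=O)C1=C(S[C@@H]2CN[C@H](C(=O)Nc3cccc(C(=O)OCOC(=O)C(C)C)c3)C2)[C@H](C)[C@@H]2[C@@H]([C@@H](C)O)C(=O)N12`, comes nearest, giving 1490 ng.h/mL in this assay, a gap beyond the scatter. Compound 3, `C[C@@H](O)[C@H]1C(=O)N2C3=C(S[C@@H]4CN[C@@H](C4)C(=O)Nc4cccc(c4)C(=O)OCc4oc(=O)oc4COC3=O)[C@H](C)[C@H]12`, lies furthest off, giving 410 ng.h/mL in this assay, also beyond the scatter. For the measured compounds named here, no step between two measured compounds that differ in one place has been recorded, so the size of any single change must be judged from compound 1 alone.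

Compound 4, `CCOC(=O)C1=C(S[C@@H]2CN[C@H](C(=O)Nc3cccc(C(=O)OCC)c3)C2)[C@H](C)[C@@H]2[C@@H]([C@@H](C)O)C(=O)N12`, differs from compound 1 in one place: hydrogen in place of propanoyl on an oxygen on a saturated carbon. Compound 4 keeps the rest of the shared core of compound 1 unchanged. Compounds 2 and 3, which also carry the 1-hydroxyethyl group, both sit below compound 1, but they differ from it elsewhere as well, so they only hint at direction. A downward step beyond the scatter, of moderate size, is expected from compound 1 to compound 4, a 2.2-fold lower number from compound 1 to compound 4 (0.35 log units; beyond the scatter). Compound 4 is therefore estimated at 2400 ng.h/mL, with a range from 900 ng.h/mL to 6000 ng.h/mL.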

Compound 4, area under the concentration-time curve: 7600 ng.h/mL
Compound 4: middle estimate off by 3.2-fold (0.50 log units), on the low side; the measured number lies above the stated range.
By their numbers in this assay, from the lowest: compound 3; then compound 2; then compounds 1 and 4 (each within the scatter of the next).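

For the compounds shown here, the change from propanoyloxy to hydroxy on the 1-(propanoyloxy)ethyl group gives the first single-place step in this assay, and it amounts to a 1.4-fold higher number from compound 1 to compound 4 (0.15 log units; within the scatter). With the rest of the shared core unchanged, this read-out does not separate propanoyl from hydrogen on this oxygen, so in this pair the propanoyl group shows no measurable bearing on exposure. Nothing available explains why the two compounds read alike.

On these data alone, whether a shorter acetyl group, a longer hexanoyl chain or an amine in place of the hydroxy would also read alike remains open. As far as these compounds go, compound 2 and compound 3 differ from compound 4 in more than one place, so the share of each of their changes in their lower numbers also remains open.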